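This account rests on a few compounds, and the source may have more. Where it says the series, first, only, none or still open, it means among the compounds named here.

Working notes on the series.

Compound 2 `C#Cc1cn([C@@H]2O[C@H](CO)[C@@H](O)[C@H]2O)c2ncnc(OC)c12` is the weakest anchor: in a functional assay on HCT-116 cells (Homo sapiens), read by MTT assay, with a stated time of 72 h (a higher number here means a weaker inhibitor, a lower number a stronger inhibitor), compound 2 gives 4060 nM. Two single changes branch from it. Compound 1 `COc1ncnc2c1c(-c1ccsc1)cn2[C@@H]1O[C@H](CO)[C@@H](O)[C@H]1O` carries thiophen-3-yl in place of ethynyl on an aromatic carbon; in this assay compound 1 gives 120 nM, which is a 34-fold lower number from compound 2 to compound 1 (1.53 log units; beyond the scatter). Compound 3 `C#Cc1cn([C@@H]2O[C@H](CO)[C@@H](O)[C@H]2O)c2ncnc(SC)c12` carries methylsulfanyl in place of methoxy on an aromatic carbon; in this assay compound 3 gives 30 nM, which is a 140-fold lower number from compound 2 to compound 3 (2.13 log units; beyond the scatter). Compound 3 holds the lowest number of the three measured, and its gaps to compound 1 and compound 2 are both beyond the scatter.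

Compound 4 `CSc1ncnc2c1c(-c1ccsc1)cn2[C@@H]1O[C@H](CO)[C@@H](O)[C@H]1O` is not yet measured. It differs from compound 3 by thiophen-3-yl in place of ethynyl on an aromatic carbon. Within the data shown here, this is the same change as the one that made the step from compound 2 to compound 1, and the place lines agree word for word, so it is the same change, now on the core of compound 3 rather than the core of compound 2; the two cores differ by methylsulfanyl in place of methoxy on an aromatic carbon. In this assay the expected step is a 10-fold lower number from compound 3 to compound 4 (1.00 log units; beyond the scatter), set somewhat smaller than the earlier one because a 34-fold lower number from compound 2 to compound 1 (1.53 log units; beyond the scatter) was measured from a far higher starting number, and a second helpful change stacked on compound 3 may not carry its full size. Among the measured compounds shown here, the expectation rests on these two measured steps only, with no second example of the thiophen-3-yl change on a methylsulfanyl core to confirm it.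

Compound 4 is therefore expected to give about 3 nM in this assay, with a plausible range from 0.6 nM to 15 nM.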

Compound 4, half-maximal inhibitory concentration: > 20000 nM
Compound 4: no number, only a limit; the forecaster's own chance of this, stated with the estimate: 5%; middle value at least 6600-fold (3.82 log units) from the limit.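

In this assay compound 4 gives > 20000 nM, and this is a limit of the assay, not a number. Thiophen-3-yl in place of ethynyl gives an at least 660-fold higher number from compound 3 to compound 4 (2.82 log units; beyond the scatter), and methylsulfanyl in place of methoxy gives an at least 160-fold higher number from compound 1 to compound 4 (2.22 log units; beyond the scatter), so each change lowers the number on one core and raises it on the other, and the thiophen-3-yl change does not carry from the core of compound 2 to the core of compound 3: the same change on two cores in this assay, a 34-fold lower number (1.53 log units; beyond the scatter) from compound 2 to compound 1 and an at least 660-fold higher number (2.82 log units; beyond the scatter) from compound 3 to compound 4, at least 22000-fold (4.35 log units) apart, beyond the scatter of two such steps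

The true size of these two new steps is not shown, nor is any cause for the reversal, and the finding rests on this one set of compounds, with compound 4 alone at the limit: the limit of > 20000 nM in this assay, at which 1 of the 4 values shown sits.

The compounds shown leave open whether the loss is particular to thiophen-3-yl on the methylsulfanyl core, or whether a phenyl ring or a short alkyl chain in place of ethynyl would fall the same way on that core. Also open, going by these compounds, is whether an amine or a longer alkylsulfanyl chain in place of methylsulfanyl would behave as methylsulfanyl does with ethynyl and with thiophen-3-yl.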